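Methyl-Bearing Thiazole Analogue: Expected Microsomal Clearance

The source may report more compounds than this note shows. Statements on the series, on what has been measured and on what is new or still open speak of the compounds shown alone.

Compound 3 `COc1ccc2c(OCC[C@@H]3NC(=O)N(C)CCCC/C=C\[C@@H]4C[C@@]4(C(=O)NS(=O)(=O)C4(C)CC4)NC3=O)cc(-n3ccc(C(C)C)n3)nc2c1C` gives 21 mL.min-1.g-1 in an ADME assay (liver) for metabolic stability, with Liver microsome (Rattus norvegicus) as the target, using microsomes, with a stated time of 2 h (a lower number here means slower removal, a higher number faster removal of the compound), the second highest of three numbers; it sits within the scatter of compound 2 `COc1ccc2c(OCC[C@@H]3NC(=O)N(C)CCCC/C=C\[C@@H]4C[C@@]4(C(=O)NS(=O)(=O)C4(C)CC4)NC3=O)cc(-c3nc(C(C)C)cs3)nc2c1Br` at 16.5 mL.min-1.g-1 and well below compound 1 `COc1ccc2c(OCC[C@@H]3NC(=O)N(C)CCCC/C=C\[C@@H]4C[C@@]4(C(=O)NS(=O)(=O)C4(C)CC4)NC3=O)cc(-c3nc(C(C)C)cs3)nc2c1` at 155 mL.min-1.g-1. Compound 4 `COc1ccc2c(OCC[C@@H]3NC(=O)N(C)CCCC/C=C\[C@@H]4C[C@@]4(C(=O)NS(=O)(=O)C4(C)CC4)NC3=O)cc(-c3nc(C(C)C)cs3)nc2c1C` differs from compound 3 by 4-isopropyl-1,3-thiazol-2-yl in place of 3-isopropyl-1H-pyrazol-1-yl on an aromatic carbon. Among the measured compounds shown here, the only measured step, a 9.4-fold lower number from compound 1 to compound 2 (0.97 log units; beyond the scatter), concerns a substituent on the core rather than this ring swap; no step separates the pyrazole from the thiazole, and compounds 2 and 3 share their low region despite differing in both places. Compound 4 keeps the methyl group, so its number is expected to stay near compound 3, with a 1.1-fold lower number from compound 3 to compound 4 (0.02 log units; within the scatter) expected to fall inside the scatter. Compound 4 is therefore estimated at 20 mL.min-1.g-1, ranging from 9 mL.min-1.g-1 to 45 mL.min-1.g-1.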

Compound 4, intrinsic clearance in microsomes: 9.3 mL.min-1.g-1
The estimate for compound 4 lay 2.2-fold (0.33 log units) above the measured number; measured number inside the range.
By their numbers in this assay, from the lowest: compounds 4, 2 and 3 (each within the scatter of the next, the first and the last beyond it); then compound 1.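

In this assay, the swap on the aromatic carbon next to the ring nitrogen now has its own step: 4-isopropyl-1,3-thiazol-2-yl in place of 3-isopropyl-1H-pyrazol-1-yl gives a 2.3-fold lower number from compound 3 to compound 4 (0.35 log units; beyond the scatter) with methyl held on the core. With the thiazole held, methyl in place of hydrogen gives a 17-fold lower number from compound 1 to compound 4 (1.22 log units; beyond the scatter) as its step. Methyl in place of bromo gives a 1.8-fold lower number from compound 2 to compound 4 (0.25 log units; within the scatter) and so does not separate these two groups. Going by these compounds, it remains open whether an amine or a longer chain in place of methyl would keep the number this low, and whether the ring swap gives the same step with hydrogen or bromo on the core. Nothing shown explains these steps.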